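The compounds below may be only part of what the source reports. "The series", "measured", "known", "first", "only" and "open" are said of these compounds alone.

Of the compounds shown here, two of a shared core have been tested in a functional assay on MCF7 cells (Homo sapiens) for antiproliferative activity, read by MTT assay, with stated times of 24 h and 72 h; on this read-out lower numbers stand for stronger inhibition and higher numbers for weaker inhibition. Compound 1 `COc1cc(N2C(=O)[C@@H](Oc3ccccc3)[C@H]2c2cccc3ccccc23)cc(OC)c1OC` gives 53000 nM, the highest of the two numbers seen so far. Compound 2 `COc1cc(N2C(=O)[C@@H](Oc3ccccc3)[C@H]2c2ccc([S+](C)[O-])cc2)cc(OC)c1OC` gives 20000 nM, and the step of a 2.7-fold lower number from compound 1 to compound 2 (0.42 log units; beyond the scatter) shows that swapping the two-ring group on the saturated ring carbon for a single-ring group can lower the number modestly. Compound 3 `COc1cc(N2C(=O)[C@@H](Oc3ccccc3)[C@H]2c2ccc(N)cc2)cc(OC)c1OC` carries a different single-ring group in the same place: 4-aminophenyl in place of naphthalen-1-yl on a saturated ring carbon. Within the data shown here, only the step from compound 1 to compound 2 bears on this change, and it was modest, so a step of similar size and direction is expected here, though the new group is not the same as in compound 2 and the outcome is uncertain. The estimate for compound 3 is 20000 nM, within 7000 nM to 60000 nM, which means an expected step of a 2.7-fold lower number from compound 1 to compound 3 (0.42 log units; beyond the scatter).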

Compound 3, half-maximal inhibitory concentration: 160000 nM
Beside the measured number, compound 3's estimate is 8.0-fold (0.90 log units) below it; measured number above the stated range.
By their numbers in this assay, from the lowest: compound 2; then compound 1; then compound 3.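

In this assay, moving from two rings to one on the saturated ring carbon does not by itself lower the number: 4-aminophenyl in place of naphthalen-1-yl gives a 3.0-fold higher number from compound 1 to compound 3 (0.48 log units; beyond the scatter), the opposite direction to a 2.7-fold lower number from compound 1 to compound 2 (0.42 log units; beyond the scatter). What the single ring carries therefore counts in these compounds, as one nitrogen atom in place of a group of carbon, oxygen and sulfur on an aromatic carbon gives an 8.0-fold higher number from compound 2 to compound 3 (0.90 log units; beyond the scatter). No measurement shown here accounts for this difference.

Still open, going by these compounds, is where an unsubstituted phenyl group in the same place would fall relative to these three compounds. It is also unknown whether a hydroxyl, a methoxy or an acetamido group on the single ring would give a number closer to that of compound 2 or compound 3.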